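A neopentyl group in place of methyl

The source may report more compounds than this note shows. Statements on the series, on what has been measured and on what is new or still open speak of the compounds shown alone.

Measured so far, all in a functional assay (strain AB) with Danio rerio as the target, read by microscopy, with a stated time of 1 h; on this read-out lower numbers stand for an effect already at smaller amounts and higher numbers for an effect only at larger amounts of compound
compound 1 `C[N+]1(CC2CCCCC2)CCc2c(sc(NC(=O)Nc3ccc(Cl)cc3)c2C(N)=O)C1` gives 100 nM
compound 2 `CN1CCc2c(sc(NC(=O)Nc3ccc(Cl)cc3)c2C(N)=O)C1` gives 4700 nM
compound 3 `CC[N+]1(CC2CC2)CCc2c(sc(NC(=O)Nc3ccc(Cl)cc3)c2C(N)=O)C1` gives 100 nM

Compound 2 (4700 nM) holds the highest of the three numbers, so it needs the largest amount of compound for an effect. Compound 1 and compound 3 share one value (100 nM), and both lie lower than compound 2 by a gap well beyond the scatter.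

Compound 4 `CC(C)(C)CN1CCc2c(sc(NC(=O)Nc3ccc(Cl)cc3)c2C(N)=O)C1` has not yet been measured. It departs from compound 2 in one place: tert-butyl in place of hydrogen on a saturated chain carbon bound to an amine nitrogen in a ring. That is tert-butyl in place of hydrogen on a saturated chain carbon bound to an amine nitrogen in a ring, so that methyl becomes neopentyl.

For the measured compounds named here, no measured pair shows a change in this one place alone, which leaves the expectation loosely founded. Compound 4 stays an uncharged amine like compound 2 (4700 nM), whereas compound 1 (100 nM) and compound 3 (100 nM) are quaternary ammonium compounds. A moderate step towards a lower number is therefore expected in this assay, probably just beyond the scatter and short of the whole gap. The expected size is a 3.1-fold lower number from compound 2 to compound 4 (0.50 log units; beyond the scatter). For compound 4 the estimated value is 1500 nM, with an expected range from 300 nM to 6000 nM.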

Compound 4, half-maximal effective concentration: 5560 nM
For compound 4 the middle estimate is 3.7-fold (0.57 log units) below the measured one; the range from low to high includes it.
By their numbers in this assay, from the lowest: compounds 1 and 3 (each within the scatter of the next); then compounds 2 and 4 (each within the scatter of the next).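

In this assay, for the compounds shown here, placing tert-butyl on a saturated chain carbon bound to an amine nitrogen in a ring gives a 1.2-fold higher number from compound 2 to compound 4 (0.07 log units; within the scatter), the first step in this set in which only one place differs. The result shows that, in this read-out, methyl and neopentyl at this place cannot be told apart, even though the entering tert-butyl brings 4 heavy atoms and no net charge. No measurement on hand offers an explanation for this outcome.

The compounds shown leave open whether this holds for other kinds of group at the same place, such as a hydroxyethyl chain, a carboxylic acid or a benzyl group, since methyl and neopentyl are the only two compared here. Going by these compounds alone, they also leave open what a second group on that amine nitrogen would do to compound 4, because compound 1 and compound 3, which carry two groups there besides the ring, differ from compound 2 and compound 4 in more than one place, so no step to them can be read.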